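Extending the Sulfonyl Side Chain: Expectations for Compound 4

The compounds below may be only part of what the source reports. "The series", "measured", "known", "first", "only" and "open" are said of these compounds alone.

Three compounds have so far been measured in a functional assay, read by fluorescence and spectrophotometry, with a stated time of 1 h; a higher number here means that more compound is needed for the effect, a lower number that less compound is needed:

Compound 1, `O=S(=O)(/C=C/c1ccc(O)c(O)c1)CCCc1ccccc1`, gives 11500 nM.
Compound 2, `CCCCCCS(=O)(=O)/C=C/c1ccc(O)c(O)c1`, gives 7300 nM.
Compound 3, `O=S(=O)(/C=C/c1ccc(O)c(O)c1)CCC1CCCC1`, gives 6800 nM.

Compound 2 stands second highest of these three numbers. Its nearest neighbour is compound 3, with a 1.1-fold lower number from compound 2 to compound 3 (0.03 log units; within the scatter). Its furthest is compound 1, with a 1.6-fold lower number from compound 1 to compound 2 (0.20 log units; within the scatter). The third comparison, a 1.7-fold lower number from compound 1 to compound 3 (0.23 log units; within the scatter), is likewise within the scatter, so the three measured compounds cannot be told apart on these numbers.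

Compound 4, `O=S(=O)(/C=C/c1ccc(O)c(O)c1)CCCCCCCCCCCO`, is the next compound to be measured. It differs from compound 2 by 5-hydroxypentyl in place of hydrogen on a saturated chain carbon, six bonds along the chain from a sulfonyl sulfur. For the measured compounds named here, none of the measured steps bears closely on this change: each of them exchanges one tail group for another at the end of the chain and none introduces a hydroxyl or lengthens the chain in this way. All three steps stayed within the scatter, and nothing in the data points in either direction for a longer chain carrying a hydroxyl. The expectation is therefore a step of no more than the scatter, a 1.0-fold higher number from compound 2 to compound 4 (0.01 log units; within the scatter), with the range widened to reflect the absence of any directly comparable step. Compound 4 is estimated at 7500 nM, within a range from 2500 nM to 22000 nM.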

Compound 4, half-maximal effective concentration: 22600 nM
Beside the measured number, compound 4's estimate is 3.0-fold (0.48 log units) below it, outside the stated range (above it).
By their numbers in this assay, from the lowest: compounds 3, 2, 1 and 4 (each within the scatter of the next, the first and the last beyond it).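

In this assay, adding 5-hydroxypentyl on a saturated chain carbon, six bonds along the chain from a sulfonyl sulfur, gives the only step shown that lies beyond the scatter (a 3.1-fold higher number from compound 2 to compound 4 (0.49 log units; beyond the scatter)). The earlier steps shown here exchanged one tail group for another and could not be told apart, so they gave no sign that the side chain mattered; this step shows that the number can respond to a change in this chain, and here more compound is needed for the effect. No measurement at hand explains this rise.

This single change both extends the chain and places a hydroxyl at its end, so the compounds shown leave open which of the two goes with the higher number, and a longer chain without the hydroxyl would be the direct comparison. Also open, as far as these compounds go, is whether the end group matters at this chain length, which an amine or a carboxylic acid in place of the hydroxyl could test, and whether a chain of intermediate length would give a smaller step.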